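Removing a methoxy group from the aryl ring of a triazole

The compounds below may be only part of what the source reports. "The series", "measured", "known", "first", "only" and "open" are said of these compounds alone.

Three compounds of one series, with a shared core and differing aryl substitution, were tested in a functional assay on the whole organism (strain albino) for inhibition, with Rattus norvegicus as the target, read by paw edema, with a stated time of 3 h, at a dose of 0.28 mmol/kg by the oral route; a higher number here means more inhibition at the dose given (going by the name of the read-out), a lower number less inhibition. Compound 1 `CCn1c(SCC(=O)c2ccccc2)nnc1-c1cc(OC)c(OC)c(OC)c1` gave 49%, compound 2 `CCn1c(SCC(=O)c2ccccc2)nnc1-c1ccc(OC)c(OC)c1` gave 61%, and compound 3 `CCn1c(SC/C(=N/O)c2ccccc2)nnc1-c1ccc(OC)cc1` gave 75%, which stands highest of the three. The change from compound 1 to compound 2 is hydrogen in place of methoxy on an aromatic carbon, and in this assay it made a number 12 percentage points higher from compound 1 to compound 2 (beyond the scatter). Compound 3 carries a different side chain and a different aryl ring from compound 1, and the difference between the two cores is not broken down here.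

Compound 4 `CCn1c(SC/C(=N/O)c2ccccc2)nnc1-c1ccccc1` has not yet been measured in this assay. It differs from compound 3 by hydrogen in place of methoxy on an aromatic carbon. For the measured compounds named here, this is the same kind of change as the one from compound 1 to compound 2, though the surroundings differ: in compound 3 the leaving group sits para to a large group, whereas in compound 1 it sits ortho to a methoxy group, meta to a large group and meta to a methoxy group. Because a number 12 percentage points higher from compound 1 to compound 2 (beyond the scatter) was modest and positive, compound 4 is expected to show a step of a number 5 percentage points higher from compound 3 to compound 4 (within the scatter) in this assay, a little smaller given how high compound 3 already reads. Compound 4 is therefore estimated at 80%, most likely between 65% and 92%.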

Compound 4, a percentage reported as inhibition, in the whole organism at one dose (the size of the read-out at that dose, not a potency): 72%
Compound 4: middle estimate off by 8 percentage points, on the high side; measured number inside the range.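

In this assay, replacing the methoxy group of the 4-methoxyphenyl ring with hydrogen gave a number 3 percentage points lower from compound 3 to compound 4 (within the scatter), so on this core the change produced no readable shift. Set beside the earlier step, the same change did not carry over from one core to the other: the same change on two cores in this assay, a number 12 percentage points higher (beyond the scatter) from compound 1 to compound 2 and a number 3 percentage points lower (within the scatter) from compound 3 to compound 4, 15 percentage points apart, beyond the scatter of two such steps

For the compounds shown here, this shows that the gain seen on the core of compound 1 cannot be assumed on the core of compound 3, but it does not show what separates the two results: the pairs differ in the side chain and in the methoxy groups left on the aryl ring, and each core offers only one pair.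

The compounds shown leave open how a plain phenyl ring would read on the core of compound 1. They also leave open what a chlorine atom or an amine would do in place of the methoxy group, and what a longer chain would do in place of the ethyl group on the shared core.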